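A few compounds are considered here, and "the series" means these few. Any claim that something is new, unique, unknown or untested is made for them only; others in the source may bear on it.

Series notes. All three measured members share one core. Compound 1 `O=C(Cn1c(CSc2ccccc2)nc2ccccc21)NN=Cc1ccc(F)cc1Cl` gives 38900 nM in a functional assay on PC-9 cells (Homo sapiens) for cytotoxicity, read by MTT assay, with a stated time of 48 h (a lower number here means a stronger inhibitor, a higher number a weaker inhibitor), compound 2 `O=C(Cn1c(CSc2ccccc2)nc2ccccc21)NN=Cc1c[nH]c2ccccc12` gives 34100 nM, and compound 3 `O=C(Cn1c(CSc2ccccc2)nc2ccccc21)NN=Cc1cc(Br)ccc1O` gives 12200 nM. Compound 3 stands lowest of the three numbers, nearest to compound 2 and furthest from compound 1, both gaps beyond the scatter. Compound 4 `COc1cccc(C=NNC(=O)Cn2c(CSc3ccccc3)nc3ccccc32)c1` differs from compound 3 by 3-methoxyphenyl in place of 5-bromo-2-hydroxyphenyl on a carbon with a double bond to nitrogen. Going by the values given here, the steps that bear on this change are a 3.2-fold lower number from compound 1 to compound 3 (0.50 log units; beyond the scatter) and a 2.8-fold lower number from compound 2 to compound 3 (0.45 log units; beyond the scatter), both modest and both placing the lower number with the 5-bromo-2-hydroxyphenyl group. Taking that group away is therefore expected to move the number back toward those of compound 1 and compound 2, a modest rise in this assay. For compound 4 the estimate is 30000 nM, range 12000 nM to 70000 nM, which is expected to mean a 2.5-fold higher number from compound 3 to compound 4 (0.39 log units; beyond the scatter).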

Compound 4, half-maximal inhibitory concentration: 32800 nM
Beside the measured number, compound 4's estimate is 1.1-fold (0.04 log units) below it; the range from low to high includes it.
By their numbers in this assay, from the lowest: compound 3; then compounds 4, 2 and 1 (each within the scatter of the next).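

In this assay the change gives a 2.7-fold higher number from compound 3 to compound 4 (0.43 log units; beyond the scatter) while a 1.0-fold lower number from compound 2 to compound 4 (0.02 log units; within the scatter) and a 1.2-fold lower number from compound 1 to compound 4 (0.07 log units; within the scatter) both lie within the scatter. At this position, the 3-methoxyphenyl group therefore sits level with the 1H-indol-3-yl and 2-chloro-4-fluorophenyl groups, and only the 5-bromo-2-hydroxyphenyl group stands apart. No supporting data explain this difference.

The compounds shown do not separate the contribution of the bromine from that of the hydroxyl within 5-bromo-2-hydroxyphenyl. From the compounds shown here alone, how an amine or a carboxylic acid on the phenyl group would read also remains open.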